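Bile acid receptor series: amide-linked biaryls and styryl analogue

The compounds below may be only part of what the source reports. "The series", "measured", "known", "first", "only" and "open" are said of these compounds alone.

Measured so far:
- compound 1, `COC(=O)/C=C/c1cccc(N(Cc2ccc(-c3ccc(F)c(Cl)c3)cc2)C(=O)C2CCCCC2)c1`, 66 nM
- compound 2, `COC(=O)/C=C/c1cccc(N(Cc2ccc(/C=C/c3c(Cl)cccc3Cl)cc2)C(=O)C2CCCCC2)c1`, 150 nM

In an assay on isolated protein with Bile acid receptor (Homo sapiens) as the target (a lower number here means that less compound is needed, a higher number that more compound is needed for the effect), compound 2 gives the highest number of the two; compound 1 sits at 66 nM, and the step from one to the other is a 2.3-fold higher number from compound 1 to compound 2 (0.36 log units; beyond the scatter). Compound 3, `COC(=O)/C=C/c1cccc(N(Cc2ccc(-c3cccc(OC(F)(F)F)c3)cc2)C(=O)C2CCCCC2)c1`, differs from compound 2 by 3-(trifluoromethoxy)phenyl in place of 2-(2,6-dichlorophenyl)ethenyl on an aromatic carbon. Within the data shown here, the only step in hand that bears on this change is a 2.3-fold higher number from compound 1 to compound 2 (0.36 log units; beyond the scatter), in which a substituted phenyl gave way to a substituted ethenyl-linked phenyl and the number rose modestly. Compound 3 returns to a directly attached substituted phenyl, though with a different substitution pattern from compound 1, so the expected step is of similar size in the opposite direction, a 2.1-fold lower number from compound 2 to compound 3 (0.33 log units; beyond the scatter). Compound 3 is therefore estimated at 70 nM in this assay , with a range from 25 nM to 200 nM.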

Compound 3, half-maximal effective concentration: 420 nM
The estimate for compound 3 lay 6.0-fold (0.78 log units) below the measured number; the measured number lies above the stated range.
By their numbers in this assay, from the lowest: compound 1; then compound 2; then compound 3.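

In this assay, a phenyl attached directly at this position does not by itself bring the number down: 3-(trifluoromethoxy)phenyl in place of 2-(2,6-dichlorophenyl)ethenyl gives a 2.8-fold higher number from compound 2 to compound 3 (0.45 log units; beyond the scatter). Among the two directly attached phenyls the substituents matter, as 3-(trifluoromethoxy)phenyl in place of 3-chloro-4-fluorophenyl gives a 6.4-fold higher number from compound 1 to compound 3 (0.80 log units; beyond the scatter), so the presence or absence of the ethenyl link alone does not order the three compounds. Nothing available accounts for these rises.

Compound 1 and compound 3 differ in both the identity and the arrangement of their phenyl substituents, so the contribution of each stays unresolved. Also open, going by these compounds, is whether an unsubstituted phenyl or a phenyl carrying a methoxy group would fall nearer compound 1 or compound 3.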